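A few compounds are considered here, and "the series" means these few. Any claim that something is new, unique, unknown or untested is made for them only; others in the source may bear on it.

Measured so far:
compound 1, `Cc1ccc(CS/C(=C/c2ccc(O)cc2)C(=O)c2ccc(Cl)cc2)cc1` — 10000 nM
compound 2, `O=C(/C(=C\c1ccc(O)cc1)SCc1ccc(Cl)cc1)c1ccc(Cl)cc1` — 10000 nM

In a functional assay on DU-145 cells (Homo sapiens) for inhibition, read by trypan blue exclusion, with a stated time of 96 h (a lower number here means a stronger inhibitor of growth, a higher number a weaker inhibitor of growth), compound 1 gives 10000 nM, and compound 2 gives 10000 nM, so the two stand level. Going by the values given here, the only measured step, no change at the digits printed from compound 1 to compound 2 (within the scatter), shows that a chloro in place of a methyl on an aromatic carbon leaves the value where it was. Compound 3, `Cc1ccc(CS/C(=C/c2ccc(Cl)cc2)C(=O)c2ccc(Cl)cc2)cc1`, differs from compound 1 at another place: chloro in place of hydroxy on an aromatic carbon. Among the compounds with values here, no measured step touches this change, so the expectation rests on the level values of compound 1 and compound 2 alone. Compound 3 is expected to give about 10000 nM, between 3000 nM and 30000 nM, which would mean a step of no change at the digits printed from compound 1 to compound 3 (within the scatter).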

Compound 3, concentration for 50% growth inhibition: 10000 nM
Compound 3: middle estimate and measured number agree at the digits printed; measured number inside the range.
By their numbers in this assay, from the lowest: compounds 1, 2 and 3 (each within the scatter of the next).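

In this assay the change from 4-hydroxyphenyl to 4-chlorophenyl gives no change at the digits printed from compound 1 to compound 3 (within the scatter) even though the hydrogen-bond donor and acceptor counted on the hydroxy leave with it. The hydroxy is therefore not required to hold this value, which the earlier pair could not show, as it differed at another place. No measured evidence explains this result.

Going by these compounds, whether an amine, a carboxylic acid or a methoxy group on this aromatic carbon would shift the number stays open. So does whether any change to the shared core can bring it lower.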